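Swapping an Aryl Tail for a Carboxyethenyl Chain

The source may report more compounds than this note shows. Statements on the series, on what has been measured and on what is new or still open speak of the compounds shown alone.

Compound 1, `COC(=O)/C=C/c1cccc(N(Cc2ccc(/C=C/c3cccc(F)c3)cc2)C(=O)C2CCCCC2)c1`, 86 nM
Compound 2, `COC(=O)/C=C/c1cccc(N(Cc2ccc(-c3ccc(SC)cc3)cc2)C(=O)C2CCCCC2)c1`, 69 nM

Two compounds share a core and differ only in the group at the end of the benzyl arm. In an assay on isolated protein with Bile acid receptor (Homo sapiens) as the target (a higher number here means that more compound is needed for the effect, a lower number that less compound is needed), compound 1 gives 86 nM, and compound 2 gives 69 nM. Compound 2 has the lowest of the two numbers, but the step of a 1.2-fold lower number from compound 1 to compound 2 (0.10 log units; within the scatter) lies within the scatter, so the two cannot be ranked. Compound 3, `COC(=O)/C=C/c1cccc(N(Cc2ccc(/C=C/C(=O)O)cc2)C(=O)C2CCCCC2)c1`, has not yet been measured. It differs from compound 2 in one place: 2-carboxyethenyl in place of 4-(methylsulfanyl)phenyl on an aromatic carbon. Among the compounds with values here, the only measured step, a 1.2-fold lower number from compound 1 to compound 2 (0.10 log units; within the scatter), exchanged 2-(3-fluorophenyl)ethenyl for 4-(methylsulfanyl)phenyl and left the number essentially unchanged; no measured pair shows what happens when the ring is removed and 2-carboxyethenyl takes its place. Within the data shown here, with no step that bears on it directly, the expectation rests on the change itself and is uncertain. For compound 3 a higher number is expected, a step of a 4.3-fold higher number from compound 2 to compound 3 (0.64 log units; beyond the scatter), with an estimate of 300 nM and a range from 70 nM to 1500 nM.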

Compound 3, half-maximal effective concentration: > 1000 nM
Compound 3 was reported as a limit; the forecaster's own chance of this, stated with the estimate: 10%; middle value at least 3.3-fold (0.52 log units) from the limit.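

Compound 3 is reported only as a limit: the limit of > 1000 nM in this assay, at which 1 of the 3 values shown sits. Even so, the change is large: replacing 4-(methylsulfanyl)phenyl with 2-carboxyethenyl gives an at least 14-fold higher number from compound 2 to compound 3 (1.16 log units; beyond the scatter), and keeping the double-bonded chain while replacing 3-fluorophenyl with carboxy gives an at least 11-fold higher number from compound 1 to compound 3 (1.06 log units; beyond the scatter). Compounds 1 and 2 had shown that two different aryl tails give values within the scatter of each other, whereas compound 3 shows that this position does not accept every group, and since compound 1 carries the same double-bonded chain, the chain alone does not go with the higher number.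

The compounds shown cannot separate the loss of the end ring from the arrival of the carboxy group. A primary amide or a hydroxymethyl group at the end of the same chain would help to tell these two apart.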